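The source may hold more compounds than are shown below. What is called first, only, known or untested is meant among the compounds shown, and "the series" means these compounds.

Working notes on the series. Compound 1 `COC1=C(N)C(=O)c2c(ccnc2-c2ccccc2)C1=O` is the reference point here. Going by the values given here, in a functional assay on the whole organism for inhibition, with Lepidium sativum as the target (on this read-out higher numbers stand for weaker inhibition and lower numbers for stronger inhibition), compound 1 gives 11300 nM, the highest of the two numbers measured so far; the nearest is compound 2 `COC1=C(N)C(=O)c2c(ccnc2-c2cccc([N+](=O)[O-])c2)C1=O`, which in this assay gives 6430 nM. Among the compounds with values here, the only measured step, a 1.8-fold lower number from compound 1 to compound 2 (0.24 log units; within the scatter), therefore tells of no real separation between the two.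

Compound 3 `COC1=C(N)C(=O)c2c(ccnc2-c2ccccc2[N+](=O)[O-])C1=O` is the next member awaiting a number. It differs from compound 1 by nitro in place of hydrogen on an aromatic carbon. Within the data shown here, the one step that bears on this change is a 1.8-fold lower number from compound 1 to compound 2 (0.24 log units; within the scatter), since there too a nitro group entered on an aromatic carbon of the same core in place of hydrogen, and that step stayed within the scatter. With a single precedent of that size, nothing beyond the scatter is expected for compound 3 in this assay; a modest move toward a lower number, of the kind seen from compound 1 to compound 2, is the most that the data support.

On that basis the estimate for compound 3 is 8500 nM, with a range from 3000 nM to 24000 nM, corresponding to a 1.3-fold lower number from compound 1 to compound 3 (0.12 log units; within the scatter), wholly an expectation until the measurement is in hand.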

Compound 3, half-maximal inhibitory concentration: 6030 nM
The estimate for compound 3 lay 1.4-fold (0.15 log units) above the measured number, within the range that was stated.
By their numbers in this assay, from the lowest: compounds 3, 2 and 1 (each within the scatter of the next).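

With nitro on an aromatic carbon ortho to a large group, the change gives a 1.9-fold lower number from compound 1 to compound 3 (0.27 log units; within the scatter) in this assay and so adds a second placement on the six-membered aromatic ring of carbon only to the earlier step, a 1.8-fold lower number from compound 1 to compound 2 (0.24 log units; within the scatter). The reading that nitro in place of hydrogen leaves this read-out within the scatter therefore no longer rests on a single step, and it holds for both nitro compounds on the shared core. Compound 2 at 6430 nM and compound 3 at 6030 nM also stand within the scatter of each other, so these numbers do not separate the two placements, and no independent evidence bears on this result.

Whether a different group on this ring, such as an amine, a carboxylic acid or a longer chain, would give a step beyond the scatter remains open, since nitro is the only substituent shown here. Also open, on these data alone, is whether any change on the shared core itself would move the number further than these nitro steps do in this assay.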